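This account rests on a few compounds, and the source may have more. Where it says the series, first, only, none or still open, it means among the compounds named here.

Compound 1, `Cc1cc(-c2ccc(Oc3ccnc(Nc4ccc(C#N)cc4)n3)c(F)c2)ccc1C#N`, was tested in a functional assay on MT4 cells (Homo sapiens) for cytotoxicity, read by MTT assay, with a stated time of 5 days; on this read-out lower numbers stand for higher toxicity in this test and higher numbers for lower toxicity in this test. In this assay compound 1 gives > 296000 nM, which is a limit of the test rather than a measured number. Two related compounds sit at the same kind of edge. Compound 2, `N#Cc1ccc(Nc2nccc(Oc3ccc(-c4ccc(C#N)cc4)cc3C(F)(F)F)n2)cc1`, gives > 273000 nM in this assay, again a limit. Compound 3, `N#Cc1ccc(Nc2nccc(Oc3ccc(-c4ccc(C#N)cc4)cc3Cl)n2)cc1`, gives > 295000 nM in this assay, also a limit. Going by the values given here, the only step that can be traced between measured compounds is a step that the two limits leave unreadable from compound 2 to compound 3, and with both of its ends at limits its size cannot be read. All three values therefore stand at the edge of the test, as shown by the limit of > 273000 nM in this assay, at which 1 of the 3 values shown sits, the limit of > 295000 nM in this assay, at which 1 of the 3 values shown sits, and (the limit of > 296000 nM in this assay, at which 1 of the 3 values shown sits), each holding one of the three compounds.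

Compound 4, `N#Cc1ccc(Nc2nccc(Oc3ccc(-c4ccc(C#N)c(F)c4)cc3F)n2)cc1`, has not yet been measured. It differs from compound 1 by fluoro in place of methyl on an aromatic carbon. Among the compounds with values here, no measured step carries this exchange, and the single traced step is unreadable, so nothing in the numbers points to a change beyond the scatter in either direction. In this assay compound 4 is therefore expected to give about 300000 nM, within a range from 150000 nM to 600000 nM. The step this estimate means, a step that the limit leaves unreadable from compound 1 to compound 4, is expected to be no change beyond the scatter, with another limit the likeliest outcome.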

Compound 4, half-maximal cytotoxic concentration: > 294000 nM
Compound 4 gave a limit, no number (the forecaster's own chance of this, stated with the estimate: 85%); the middle value lies beyond the limit too.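

In this assay compound 4 gives > 294000 nM, which is a limit and not a number. Compound 1 also stands at a limit, and the step from compound 1 to compound 4 cannot be read. Where the true half-maximal cytotoxic concentration of any of the four compounds lies stays open, and with it whether fluoro in place of methyl changes anything.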